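The source may report more compounds than this note shows. Statements on the series, on what has been measured and on what is new or still open speak of the compounds shown alone.

Measured compounds in a physicochemical assay for lipophilicity, read by LC-MS, in phosphate buffer, measured as octanol-water partition, with a stated time of 30 min, at pH 7.4, tested at 200 mM; on this read-out higher numbers stand for higher lipophilicity and lower numbers for lower lipophilicity:
Compound 1 `Cn1c(COc2cccc(C(=O)O)c2)nc2ccc(Oc3ccc4c(c3)CCC4)nc21` gives 2.5.
Compound 2 `Cn1c(COc2cccc(C(=O)O)c2)nc2cnc(Oc3ccc(Cl)c(F)c3)cc21` gives 1.4.
Compound 3 `Cn1c(COc2cccc(C(=O)O)c2)nc2ccc(Oc3cc(Cl)ccn3)cc21` gives 1.2.

Compound 3 carries the lowest of the three numbers, but its gap to compound 2 lies within the usual scatter, so the two cannot be separated; only compound 1 stands clearly apart, beyond the scatter.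

Compound 4 `Cc1cc(Cl)cnc1Oc1ccc2nc(COc3cccc(C(=O)O)c3)n(C)c2c1` has not yet been measured. It differs from compound 3 in one place: 5-chloro-3-methylpyridin-2-yl in place of 4-chloropyridin-2-yl on an oxygen on an aromatic ring. Going by the values given here, with no measured step of this kind to lean on, the expected shift in this assay is a modest rise, a little beyond the scatter, with the added carbon of the entering group as the only guide.

On that basis compound 4 is estimated at 1.6, between 1.2 and 2, which would mean an expected step of a number 0.40 log units higher from compound 3 to compound 4 (beyond the scatter).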

Compound 4, distribution coefficient: 1.8
Compound 4: the middle estimate sits 0.20 log units below what was measured; the measured number falls inside the stated range.
By their numbers in this assay, from the lowest: compounds 3 and 2 (each within the scatter of the next); then compound 4; then compound 1.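

In this assay, going by these compounds alone, 5-chloro-3-methylpyridin-2-yl in place of 4-chloropyridin-2-yl on an oxygen on an aromatic ring gives a number 0.60 log units higher from compound 3 to compound 4 (beyond the scatter) and so provides the first one-place comparison. It shows that the reading responds to a change at this position, even though both groups are six-membered aromatic rings with one hetero atom and the count rises by only one carbon. No measurement at hand accounts for the size of this step.

On these data alone, whether the rise follows the methyl or the changed place of the chlorine stays open. So does the reading with an amine or a longer alkyl chain on this oxygen.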